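Positional isomers of a trifluoromethylphenyl pyridine and T47D inhibition

The source may report more compounds than this note shows. Statements on the series, on what has been measured and on what is new or still open speak of the compounds shown alone.

Measured compounds:
compound 1, `Oc1ccccc1-c1cc(-c2cccc(C(F)(F)F)c2)cc(-c2ccccc2O)n1`, > 50000 nM
compound 2, `Oc1ccccc1-c1cc(-c2ccc(C(F)(F)F)cc2)cc(-c2ccccc2O)n1`, > 50000 nM
compound 3, `Oc1cccc(-c2cc(-c3cccc(C(F)(F)F)c3)cc(-c3ccccc3O)n2)c1`, 6340 nM

Of the compounds shown here, three have been measured in a functional assay on T47D cells (Homo sapiens) for inhibition; a higher number here means a weaker inhibitor, a lower number a stronger inhibitor. For compound 1 the value > 50000 nM is a limit of the assay, not a number. For compound 2 the value > 50000 nM is likewise a limit. Among the compounds with values here, compound 3 is the only one that gives a number, 6340 nM in this assay, and it is reached from compound 1 by the change (3-hydroxyphenyl in place of 2-hydroxyphenyl on an aromatic carbon), which gives an at least 7.8-fold lower number from compound 1 to compound 3 (0.89 log units; beyond the scatter).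

The change from compound 1 to compound 2 is 4-(trifluoromethyl)phenyl in place of 3-(trifluoromethyl)phenyl on an aromatic carbon; its step is a step that the two limits leave unreadable from compound 1 to compound 2, which rests on (the limit of > 50000 nM in this assay, at which 2 of the 3 values shown sit).

Compound 4, `Oc1cccc(-c2cc(-c3ccc(C(F)(F)F)cc3)cc(-c3ccccc3O)n2)c1`, is not yet measured. It differs from compound 3 by 4-(trifluoromethyl)phenyl in place of 3-(trifluoromethyl)phenyl on an aromatic carbon. This is the same kind of change as that from compound 1 to compound 2, though the surroundings differ: in compound 1 the place is meta to two 2-hydroxyphenyl groups, whereas in compound 3 it is meta to a 2-hydroxyphenyl group and meta to a 3-hydroxyphenyl group. Within the data shown here, because the step from compound 1 to compound 2 is a step that the two limits leave unreadable from compound 1 to compound 2, the only precedent for this change gives no readable size.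

With no readable precedent, the expectation for compound 4 is a step of about a 1.3-fold higher number from compound 3 to compound 4 (0.10 log units; within the scatter) from compound 3 in this assay, that is, a value not far from that of compound 3 and within or near the scatter. Compound 4 is therefore estimated at 8000 nM, with a range from 2500 nM to 30000 nM.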

Compound 4, half-maximal inhibitory concentration: > 50000 nM
Compound 4 ended at the assay's limit (the forecaster's own chance of this, stated with the estimate: 25%); middle value at least 6.2-fold (0.79 log units) from the limit.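

In this assay, going by these compounds, placing 4-(trifluoromethyl)phenyl in place of 3-(trifluoromethyl)phenyl on the core that carries one 2-hydroxyphenyl group and one 3-hydroxyphenyl group gives an at least 7.8-fold higher number from compound 3 to compound 4 (0.89 log units; beyond the scatter), so on this core the change is not neutral, and the full size of the step stays unknown. For compound 4 the value > 50000 nM is a limit of the assay, not a number. The same change on the core of compound 1 cannot be read, and neither can the swap of 2-hydroxyphenyl for 3-hydroxyphenyl between compound 2 and compound 4, because both members of each pair sit at the limit, so the series shows the change on one core only and does not show whether it would have the same size on the other: the limit of > 50000 nM in this assay, at which 3 of the 4 values shown sit.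

The compounds shown leave open whether any other group at this place on the shared core, such as an amine or a carboxylic acid in place of the trifluoromethyl group, would keep a readable number in this assay. They also leave open how a second 3-hydroxyphenyl group, in place of the remaining 2-hydroxyphenyl group, would read on either trifluoromethylphenyl isomer.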